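Changing the Amide Aryl Group: From Compound 3 to Compound 4

A few compounds are considered here, and "the series" means these few. Any claim that something is new, unique, unknown or untested is made for them only; others in the source may bear on it.

Measured so far:
Compound 1, `CC(C)(C)OC(=O)N1C[C@@H](n2cc(-c3ccc4c(N)n[nH]c4c3)nn2)C[C@H]1C(=O)Nc1ccc(Cl)c(C(F)(F)F)c1`: 37.1%
Compound 2, `CC(C)(C)OC(=O)N1C[C@@H](n2cc(-c3ccc4c(N)n[nH]c4c3)nn2)C[C@H]1C(=O)Nc1ccc(Cl)cc1Cl`: 25.6%
Compound 3, `CC(C)(C)OC(=O)N1C[C@@H](n2cc(-c3ccc4nc(N)sc4n3)nn2)C[C@H]1C(=O)Nc1ccc(Cl)c(C(F)(F)F)c1`: 27.4%

These three compounds were tested in a functional assay on K562/Adr cells (Homo sapiens) for inhibition, read by MTT assay, with a stated time of 48 h, tested at 30 uM; a higher number here means more inhibition at the concentration tested (going by the name of the read-out), a lower number less inhibition. Compound 3 gives 27.4%, a number that lies between those of compound 1 and compound 2, although both gaps are within the usual scatter, so no ranking among the three can be claimed with confidence. The new compound 4, `CC(C)(C)OC(=O)N1C[C@@H](n2cc(-c3ccc4nc(N)sc4n3)nn2)C[C@H]1C(=O)Nc1ccc(Cl)cc1Cl`, has not yet been measured in this assay. It differs from compound 3 in one place: 2,4-dichlorophenyl in place of 4-chloro-3-(trifluoromethyl)phenyl on an amide-type nitrogen.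

The same change has already been made once, on the core of compound 1, where it gave a number 11.5 percentage points lower from compound 1 to compound 2 (beyond the scatter). The difference between the core of compound 1 and the core of compound 3 gave a number 9.7 percentage points lower from compound 1 to compound 3 (within the scatter), so the two cores behaved alike within the scatter. For the measured compounds named here, with only one earlier example of the aryl swap, the expectation for compound 4 rests on that single step: a modest decrease, expected to be a number 11.4 percentage points lower from compound 3 to compound 4 (beyond the scatter). Compound 4 is therefore estimated to give 16%, with a range from 4% to 28%.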

Compound 4, a percentage reported as inhibition, at one concentration (the size of the read-out at that concentration, not a potency): 28.3%
The estimate for compound 4 lay 12.3 percentage points below the measured number; measured number above the stated range.
By their numbers in this assay, from the lowest: compounds 2, 3, 4 and 1 (each within the scatter of the next, the first and the last beyond it).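

In this assay, 2,4-dichlorophenyl in place of 4-chloro-3-(trifluoromethyl)phenyl on the amide-type nitrogen gives a number 0.9 percentage points higher from compound 3 to compound 4 (within the scatter), so the drop seen with this change on the core of compound 1 does not appear on this second core. Exchanging the cores while keeping 2,4-dichlorophenyl gives a number 2.7 percentage points higher from compound 2 to compound 4 (within the scatter), and this step can be set against the same exchange made with the other aryl group: the same change on two cores in this assay, a number 9.7 percentage points lower (within the scatter) from compound 1 to compound 3 and a number 2.7 percentage points higher (within the scatter) from compound 2 to compound 4, 12.4 percentage points apart, within the scatter of two such steps. The aryl change therefore has no single, transferable size across these two cores, yet the data do not establish that its outcome truly depends on the core: the same change on two cores in this assay, a number 11.5 percentage points lower (beyond the scatter) from compound 1 to compound 2 and a number 0.9 percentage points higher (within the scatter) from compound 3 to compound 4, 12.4 percentage points apart, within the scatter of two such steps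

All four compounds were read at a single concentration and sit in a narrow band, so they give no potency and leave open whether either aryl group or either core matters much for this read-out. Also open, as far as these compounds go, is whether a nitrile or methoxy group on the amide aryl ring, or a free amine in place of the tert-butyl carbamate, would move the number clear of the scatter.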